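From hydroxy to nitro on a shared core

The compounds below may be only part of what the source reports. "The series", "measured", "known", "first", "only" and "open" are said of these compounds alone.

Values from a functional assay on HT-29 cells (Homo sapiens) for inhibition, read by MTT assay; a higher number here means a weaker inhibitor, a lower number a stronger inhibitor
compound 1 `COc1ccc(/C=C2\c3cc(OC)c(OC)c(OC)c3CC[C@@H]2O)cc1[N+](=O)[O-]` gives 1590 nM
compound 2 `COc1ccc(/C=C2\c3cc(OC)c(OC)c(OC)c3CC[C@H]2O)cc1C#N` gives 200 nM
compound 3 `COc1ccc(/C=C2\c3cc(OC)c(OC)c(OC)c3CC[C@H]2O)cc1O` gives 790 nM

Compound 3 at 790 nM lies within the scatter of compound 1, while compound 2 sits lower. The next case is compound 4 `COc1ccc(/C=C2\c3cc(OC)c(OC)c(OC)c3CC[C@H]2O)cc1[N+](=O)[O-]`, which carries nitro in place of hydroxy on an aromatic carbon. The closest guide is a 4.0-fold higher number from compound 2 to compound 3 (0.60 log units; beyond the scatter), a modest change at this same place. Read backwards, it shows that replacing hydroxy with cyano lowers the number, though nitro is a different group. Compound 1 also carries nitro, at 1590 nM, but as a different stereoisomer, so it guides only loosely. A modest drop in this assay is therefore expected, with a 2.0-fold lower number from compound 3 to compound 4 (0.30 log units; within the scatter) as the estimated step. Compound 4 is estimated at 400 nM, with an expected range of 130 nM to 1200 nM.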

Compound 4, half-maximal inhibitory concentration: > 10000 nM
Compound 4 ended at the assay's limit; the forecaster's own chance of this, stated with the estimate: 1%; middle value at least 25-fold (1.39 log units) from the limit.
By their numbers in this assay, from the lowest: compound 2; then compounds 3 and 1 (each within the scatter of the next). At a limit, above all of these: compound 4.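

In this assay compound 4 stands at a limit, not at a number: the limit of > 10000 nM in this assay, at which 1 of the 4 values shown sits. For the compounds shown here, on this aromatic carbon, the choice of group can matter far more than the earlier compounds showed, with an at least 12-fold higher number from compound 3 to compound 4 (1.10 log units; beyond the scatter) and an at least 50-fold higher number from compound 2 to compound 4 (1.69 log units; beyond the scatter). Nitro alone does not set the result, as an at least 6.2-fold higher number from compound 1 to compound 4 (0.79 log units; beyond the scatter) spans two compounds that share it: the fact that compounds 1 and 4 differ only in the configuration as drawn.

On these data alone, how far compound 4 lies past its limit stays open, so these steps are only minimum sizes. Also open, as far as these compounds go, are how an amine or a carboxylic acid would behave on this carbon, and whether the other drawn configuration would shift the hydroxy and cyano compounds.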